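Allyl for hydroxyethyl on a brominated adenine core

A few compounds are considered here, and "the series" means these few. Any claim that something is new, unique, unknown or untested is made for them only; others in the source may bear on it.

Measured so far:
compound 1 `Nc1ncnc2ncn(CCCO)c12` — a limit in this assay: > 100000 nM
compound 2 `CC(O)Cn1c(Br)nc2c(N)ncnc21` — a limit in this assay: >= 100000 nM

In an assay on CHO cells for displacement of a labelled ligand from adenosine receptor A3 (Homo sapiens) (a lower number here means a stronger inhibitor, a higher number a weaker inhibitor), compound 1 reaches only a limit, (the limit of > 100000 nM in this assay, at which 1 of the 2 values shown sits). Compound 2 likewise stops at a limit, (the limit of >= 100000 nM in this assay, at which 1 of the 2 values shown sits). On the numbers shown compound 2 therefore stands nowhere in particular: neither it nor compound 1 gives a number, and no step between them can be read, so nothing is said about their order.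

The next compound, compound 3 `C=CCCn1c(Br)nc2c(N)ncnc21`, carries allyl in place of 1-hydroxyethyl on a saturated chain carbon bound to an aromatic nitrogen; the hydroxyl of compound 2 is gone and a double bond outside the aromatic rings arrives in its place, at the same length of chain. Among the compounds with values here, no measured step bears on this change. With both known compounds at the limit, the step of a number no higher from compound 2 to compound 3 (the limit leaves the size open) is expected to be none beyond the scatter, and a further limit is the likeliest outcome. Compound 3 is expected to give about 100000 nM in this assay, with a range from 20000 nM to 300000 nM; a measurement below that range would be the notable result.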

Compound 3, inhibition constant: > 100000 nM
Compound 3 ended at the assay's limit; the forecaster's own chance of this, stated with the estimate: 70%; the middle value lies on the limit itself.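

Within the data shown here, compound 3 gives only a limit in this assay, > 100000 nM, and compound 2 also gives only a limit, >= 100000 nM, so no step between compound 2 and compound 3 can be read. The compounds shown leave open whether any group on this chain gives a measurable value in this assay, and how allyl and 1-hydroxyethyl would then compare.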